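The source may report more compounds than this note shows. Statements on the series, on what has been measured and on what is new or still open speak of the compounds shown alone.

Measured compounds in an ADME assay on Vero cells (Chlorocebus sabaeus) for cytotoxicity, read by MTT assay, with a stated time of 72 h; on this read-out higher numbers stand for weaker inhibition and lower numbers for stronger inhibition:
Compound 1 `O=C(c1ccncc1)N1N=C(c2cc3ccccc3o2)CC1c1ccccc1O` gives only a limit, > 195000 nM.
Compound 2 `COc1ccccc1C1CC(c2cc3ccccc3o2)=NN1C(=O)c1ccncc1` gives only a limit, > 202000 nM.
Compound 3 `O=C(O)c1ccccc1C1CC(c2cc3ccccc3o2)=NN1C(=O)c1ccncc1` gives only a limit, > 170000 nM.

Among the measured compounds shown here, compound 1 thus stands at a limit, and the two further values shown are limits too, so no compound can be ranked against another. Compound 4 `O=C(c1ccncc1)N1N=C(c2cc3ccccc3o2)CC1c1cccc([N+](=O)[O-])c1` differs from compound 1 in one place: 3-nitrophenyl in place of 2-hydroxyphenyl on a saturated ring carbon. The measured steps that change the same saturated ring carbon are a step that the two limits leave unreadable from compound 1 to compound 2 and a step that the two limits leave unreadable from compound 1 to compound 3; both are unreadable, the values behind them being the limits (the limit of > 170000 nM in this assay, at which 1 of the 3 values shown sits), the limit of > 195000 nM in this assay, at which 1 of the 3 values shown sits, and (the limit of > 202000 nM in this assay, at which 1 of the 3 values shown sits). For the measured compounds named here, no step of known size exists, so no change beyond the scatter is expected in this assay. Compound 4 is expected to give 200000 nM, within 80000 nM to 500000 nM. The expected step is a step that the limit leaves unreadable from compound 1 to compound 4, most likely reported again as a limit.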

Compound 4, half-maximal inhibitory concentration: > 240000 nM
Compound 4 gave a limit, no number (the forecaster's own chance of this, stated with the estimate: 80%); middle value at least 1.2-fold (0.07 log units) from the limit.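

In this assay, among the compounds shown here, compound 4 gives only a limit, as do compound 1, compound 2 and compound 3, so no step among them can be read. The compounds shown leave open whether changing the group on the saturated ring carbon alters this read-out at all.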